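Three Dichloroanilino Pyridines and Pyrimidines at the Assay Limit

This account rests on a few compounds, and the source may have more. Where it says the series, first, only, none or still open, it means among the compounds named here.

Compound 1 `Nc1cccc(Nc2cc(Cl)cc(Cl)c2)n1` — > 180000 nM
Compound 2 `Cc1cc(N)cc(Nc2cc(Cl)cc(Cl)c2)n1` — > 180000 nM
Compound 3 `Cc1cc(Nc2cc(Cl)cc(Cl)c2)ncn1` — > 180000 nM

Each of these three values is a limit of the assay and not a number. All three compounds were tested in an assay on cells for inhibition of S-adenosylmethionine decarboxylase proenzyme (Homo sapiens), read by mass spectrometry, at pH 7.2; on this read-out lower numbers stand for stronger inhibition and higher numbers for weaker inhibition. Compound 1 gives > 180000 nM, a limit. Compound 2 gives > 180000 nM, also a limit. Compound 3 gives > 180000 nM, again a limit. So compound 3 stands where every compound shown stands: at the limit of this assay, as the limit of > 180000 nM in this assay, at which 3 of the 3 values shown sit, records, with no measured inhibition to compare against.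

Compound 4 `Cc1cc(Nc2cc(Cl)cc(Cl)c2)nc(N(C)C)n1` has not yet been measured. It differs from compound 3 by dimethylamino in place of hydrogen on an aromatic carbon. No step between two measured compounds is available, so nothing shown tells how this assay answers to a change of this kind. Given that compound 3 sits at the limit with > 180000 nM, the expectation for compound 4 is a step that the limit leaves unreadable from compound 3 to compound 4 of no size beyond the scatter, in either direction. Compound 4 is therefore estimated at 200000 nM, within a range from 40000 nM to 1000000 nM, most likely reported again only as a limit.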

Compound 4, half-maximal inhibitory concentration: > 180000 nM
Compound 4: a limit, no number; the forecaster's own chance of this, stated with the estimate: 80%; the middle value does not contradict the limit.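

Compound 3 and compound 4 each give only a limit and not a number, so no step between them can be read: the limit of > 180000 nM in this assay, at which 4 of the 4 values shown sit.

The compounds shown leave open whether any change to the shared core would give a measurable inhibition in this assay.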